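A 2-hydroxycycloheptyl group on the shared core

This account rests on a few compounds, and the source may have more. Where it says the series, first, only, none or still open, it means among the compounds named here.

Going by the values given here, in an ADME assay on microsomes from liver (Mus musculus) for metabolic stability, with a stated time of 10 min (on this read-out lower numbers stand for a less stable compound and higher numbers for a more stable compound), compound 1 (`Cc1c(Cl)cccc1Oc1cccn2c(C3CCOCC3)nnc12`) gives 100%, the only number available in this small set. Compound 2 (`Cc1c(Cl)cccc1Oc1cccn2c(C34CCC(N)(CC3)CC4)nnc12`) carries the same core, but its entry reads "not determined" (no result reported), so compound 2 has no place on the scale and offers no starting value. Compound 3 (`Cc1c(Cl)cccc1Oc1cccn2c(C3CCCCCC3O)nnc12`) has not yet been measured. It differs from compound 2 in one place, (a group of 8 heavy atoms (7 carbon, 1 oxygen; one seven-membered non-aromatic ring of carbon only) in place of a group of 9 heavy atoms (8 carbon, 1 nitrogen; 2 six-membered non-aromatic rings of carbon only), on an aromatic carbon), with a 2-hydroxycycloheptyl group now on the aromatic carbon of the five-membered aromatic ring.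

Among the compounds with values here, without a value for compound 2, no step from it can be sized, and no measured step shows what such a change does in this assay. Within the data shown here, the sole anchor is compound 1 at 100%, and a reading there can hardly go higher. A moderate drop from that reading, somewhat beyond the scatter, is therefore expected, though this is a judgement with little data behind it. For compound 3 the estimated value is 75%, with an expected range of 45% to 98%.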

Compound 3, percent of the compound remaining: 43%
For compound 3 the middle estimate is 32 percentage points above the measured one, and the stated range ends above it.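

In this assay, the step of a number 57 percentage points lower from compound 1 to compound 3 (beyond the scatter) shows that the group on this aromatic carbon of the five-membered aromatic ring is not indifferent: replacing oxan-4-yl with 2-hydroxycycloheptyl on the shared core moves the read-out well beyond the scatter. Going by these compounds alone, compound 3, at 43%, also gives the set a reading clear of the top of the scale, which compound 1 alone could not provide, and this is the only readable step at this position. Nothing in the data shown explains the size of this step.

Within the data shown here, the single step changes the ring and adds a hydroxyl group at once, so it remains open whether the lower number goes with the seven-membered carbon ring, with the hydroxyl group or with both, and a plain cycloheptyl group or a 4-hydroxycyclohexyl group at the same place would be needed to tell these apart. The step between compound 2 and compound 3 cannot be read, which leaves open how a group carrying an amine compares with 2-hydroxycycloheptyl at this position.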